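Meta hydroxy in place of fluoro on the thioether arm

The source may hold more compounds than are shown below. What is called first, only, known or untested is meant among the compounds shown, and "the series" means these compounds.

Compound 1 `C[C@@H](Sc1nc2c(cnn2C)c(=O)n1-c1ccccc1)c1ccccc1` carries a 1-phenylethyl group on the sulfur and gives 40 nM in an assay on isolated protein for inhibition of retinal dehydrogenase 2 (Homo sapiens); on this read-out higher numbers stand for weaker inhibition and lower numbers for stronger inhibition. Compound 2 `CC(Sc1nc2c(cnn2C)c(=O)n1-c1ccccc1)c1cccc(F)c1` carries 1-(3-fluorophenyl)ethyl in its place; in this assay compound 2 gives 110 nM, which is the highest of the two numbers recorded so far, and the step of a 2.8-fold higher number from compound 1 to compound 2 (0.44 log units; beyond the scatter) sets it apart from compound 1.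

Compound 3 `CC(Sc1nc2c(cnn2C)c(=O)n1-c1ccccc1)c1cccc(O)c1` differs from compound 2 by hydroxy in place of fluoro on an aromatic carbon, on an aromatic carbon of the six-membered carbon ring, meta to a large group. For the measured compounds named here, no measured step exchanges one meta substituent for another; the only step that touches this ring, from compound 1 to compound 2, shows that a meta substituent shifts this read-out by a modest amount. The expectation is therefore a step of a 1.4-fold higher number from compound 2 to compound 3 (0.13 log units; within the scatter), with no firm direction. For compound 3 in this assay the estimate is 150 nM, expected to fall between 50 nM and 500 nM.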

Compound 3, half-maximal inhibitory concentration: 100 nM
Estimate against measurement, compound 3: 1.5-fold (0.18 log units) above; the range from low to high includes it.
By their numbers in this assay, from the lowest: compound 1; then compounds 3 and 2 (each within the scatter of the next).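

Working notes: in this assay, hydroxy in place of fluoro gives a 1.1-fold lower number from compound 2 to compound 3 (0.04 log units; within the scatter), so these two groups cannot be told apart on this read-out, although the entering hydroxy counts one hydrogen-bond donor and one hydrogen-bond acceptor and the leaving fluoro counts neither. The second substituted compound also stands apart from the unsubstituted arm, with a 2.5-fold higher number from compound 1 to compound 3 (0.40 log units; beyond the scatter), a step of much the same size as a 2.8-fold higher number from compound 1 to compound 2 (0.44 log units; beyond the scatter), and neither substituted compound goes against this pattern. No measurement available here accounts for this result.

Still open, going by these compounds, is whether an amine, a carboxylic acid or a methoxy group at this position would stay level with fluoro and hydroxy. Compound 1 is drawn with a defined configuration at the carbon on sulfur, while compound 2 and compound 3 are drawn without one, so the part played by that configuration in both steps from compound 1 remains unresolved.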